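Swapping a Methyl for a Nitrile on the Phenyl Group

The source may hold more compounds than are shown below. What is called first, only, known or untested is meant among the compounds shown, and "the series" means these compounds.

Of the compounds shown here, three built on one shared core have been measured so far. Compound 1 `Cc1ccccc1-n1cc(CN2C(=O)C[C@@H]3CC[C@@]2(C)C3(C)C)nn1` gives 90 nM in a functional assay on A549 cells (Homo sapiens) for inhibition, read by MTT assay, with a stated time of 24 h; on this read-out lower numbers stand for stronger inhibition and higher numbers for weaker inhibition. Compound 2 `CC1(C)[C@H]2CC[C@]1(C)N(Cc1cn(-c3ccccc3O)nn1)C(=O)C2` gives 230 nM in this assay, and compound 3 `Cc1ccc(-n2cc(CN3C(=O)C[C@@H]4CC[C@@]3(C)C4(C)C)nn2)cc1` gives 400 nM in this assay. On these numbers compound 3 stands highest of the three: the step of a 1.7-fold higher number from compound 2 to compound 3 (0.24 log units; within the scatter) is within the scatter, but a 4.4-fold higher number from compound 1 to compound 3 (0.65 log units; beyond the scatter) is beyond it, so compound 3 is weaker than compound 1 while not separable from compound 2.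

Compound 4 `CC1(C)[C@H]2CC[C@]1(C)N(Cc1cn(-c3ccccc3C#N)nn1)C(=O)C2` is not yet measured. It differs from compound 3 in one place: 2-cyanophenyl in place of 4-methylphenyl on an aromatic nitrogen. Within the data shown here, two measured steps bear on this. The step of a 4.4-fold higher number from compound 1 to compound 3 (0.65 log units; beyond the scatter) shows that going from 2-methylphenyl to 4-methylphenyl weakened inhibition, and compound 4 again carries a 2-substituted phenyl, as compound 1 does, though its group is now a nitrile. The step of a 2.6-fold higher number from compound 1 to compound 2 (0.41 log units; beyond the scatter) shows that exchanging methyl for hydroxy on that phenyl cost some potency, so the identity of the group also matters. Taken together, a modest lowering of the number is expected for compound 4, a 2.0-fold lower number from compound 3 to compound 4 (0.30 log units; within the scatter). Compound 4 is therefore estimated to give 200 nM, within a range of 80 nM to 500 nM.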

Compound 4, half-maximal inhibitory concentration: 100 nM
Estimate against measurement, compound 4: 2.0-fold (0.30 log units) above; the measured number falls inside the stated range.
By their numbers in this assay, from the lowest: compounds 1 and 4 (each within the scatter of the next); then compounds 2 and 3 (each within the scatter of the next).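

In this assay the 2-cyanophenyl group on the aromatic nitrogen does clearly better than the 4-methylphenyl group, with a 4.0-fold lower number from compound 3 to compound 4 (0.60 log units; beyond the scatter) as the new step, while a 1.1-fold higher number from compound 1 to compound 4 (0.05 log units; within the scatter) means that 2-cyanophenyl and 2-methylphenyl cannot be told apart here. This position therefore accepts a nitrile as readily as a methyl, and the two very different groups share a low number, but compound 2 goes against any rule that every 2-substituted phenyl does equally well: a 2.3-fold lower number from compound 2 to compound 4 (0.36 log units; beyond the scatter) sets the 2-hydroxyphenyl group apart from the nitrile, just as a 2.6-fold higher number from compound 1 to compound 2 (0.41 log units; beyond the scatter) set it apart from the methyl. No measurement is available that explains why these groups differ.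

Compound 3 and compound 4 differ both in the group and in where it sits on the phenyl, so these compounds cannot show how much of the step belongs to each. As far as these compounds go, it also remains open whether an amine, a carboxylic acid or a chlorine on that phenyl would match the methyl and the nitrile or would fall with the hydroxy.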